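Replacing 3-nitrophenyl with 4-cyanophenyl

The compounds below may be only part of what the source reports. "The series", "measured", "known", "first", "only" and "open" are said of these compounds alone.

In a functional assay on HepG2 cells (Homo sapiens) for cytotoxicity, read by MTT assay, with a stated time of 24 h (on this read-out higher numbers stand for weaker inhibition and lower numbers for stronger inhibition), compound 1 (`CN1C/C(=C\c2ccc(Br)cc2)C(=O)/C(=C/c2cccc([N+](=O)[O-])c2)C1`) gives 8800 nM and compound 2 (`CN1C/C(=C\c2ccc(C(F)(F)F)cc2)C(=O)/C(=C/c2cccc([N+](=O)[O-])c2)C1`) gives 1040 nM, the lower of the two numbers. Going by the values given here, the single measured step, an 8.5-fold lower number from compound 1 to compound 2 (0.93 log units; beyond the scatter), is trifluoromethyl in place of bromo on an aromatic carbon.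

Next is compound 3 (`CN1C/C(=C\c2ccc(C#N)cc2)C(=O)/C(=C/c2ccc(C(F)(F)F)cc2)C1`), with 4-cyanophenyl in place of 3-nitrophenyl on a double-bonded chain carbon bound to a double-bonded ring carbon. Among the compounds with values here, no measured step covers this change, so its size and direction have no direct precedent. Within the data shown here, the one step shows only that a single replacement elsewhere can move the number in this assay beyond the scatter. Compound 2 holds the lower number at 1040 nM, so a modest rise is tentatively expected. The expected step is a 1.7-fold higher number from compound 2 to compound 3 (0.24 log units; within the scatter). The estimated value for compound 3 is 1800 nM, with a range of 450 nM to 7000 nM.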

Compound 3, half-maximal inhibitory concentration: 980 nM
Beside the measured number, compound 3's estimate is 1.8-fold (0.26 log units) above it; low and high end bracket the measured number.
By their numbers in this assay, from the lowest: compounds 3 and 2 (each within the scatter of the next); then compound 1.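

In this assay the step at this position, on a double-bonded chain carbon bound to a double-bonded ring carbon, is a 1.1-fold lower number from compound 2 to compound 3 (0.03 log units; within the scatter) and stays within the scatter, so 3-nitrophenyl and 4-cyanophenyl cannot be told apart here with the 4-(trifluoromethyl)phenyl group present in both compounds. The earlier step, an 8.5-fold lower number from compound 1 to compound 2 (0.93 log units; beyond the scatter), showed a change beyond the scatter from a replacement elsewhere, whereas this swap of nitro-bearing for nitrile-bearing aromatic ring, with 2 hydrogen-bond acceptors leaving and 1 entering, shows none. Nothing available explains why the number holds across this change.

Open, as far as these compounds go, is whether this position also accepts a non-aromatic group such as an amine, a carboxylic acid or a longer chain. Also open, from the compounds shown here alone, is whether 4-cyanophenyl gives the same result when bromo replaces trifluoromethyl on the other aromatic ring.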